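The source may hold more compounds than are shown below. What is called first, only, known or untested is meant among the compounds shown, and "the series" means these compounds.

Among the compounds with values here, in a functional assay on MDA-MB-231 cells (Homo sapiens) for inhibition, read by sulforhodamine B assay (on this read-out higher numbers stand for weaker inhibition and lower numbers for stronger inhibition), compound 3 `CCCCNc1ccc(CC#CCOc2c(C/C=C(\C)CCC(=O)OC)c(OC)c(C)c3c2C(=O)OC3)cc1` gives 19800 nM, the only true number in the set. Compound 1 `COC(=O)CC/C(C)=C/Cc1c(OC)c(C)c2c(c1OCC#CCN1CCCc3ccccc31)C(=O)OC2` reads > 50000 nM, which is a limit of the assay. Compound 2 `COC(=O)CC/C(C)=C/Cc1c(OC)c(C)c2c(c1OCC#CCN1CCC(Cc3ccccc3)CC1)C(=O)OC2` reads > 50000 nM, also a limit. Compound 4 `COC(=O)CC/C(C)=C/Cc1c(OC)c(C)c2c(c1OCC#CCN1CCC(C(=O)OC)CC1)C(=O)OC2` differs from compound 3 as follows: 4-(methoxycarbonyl)piperidin-1-yl in place of 4-(butylamino)phenyl on a saturated chain carbon bound to a triple-bonded carbon. This puts 4-(methoxycarbonyl)piperidin-1-yl in place of 4-(butylamino)phenyl on a saturated chain carbon bound to a triple-bonded carbon. Within the data shown here, the one measured step bearing on this is an at least 2.5-fold lower number from compound 1 to compound 3 (0.40 log units; beyond the scatter), which introduced the 4-(butylamino)phenyl that now leaves. A loss of similar modest size or somewhat more is therefore expected, toward weaker inhibition. The expected change is a 2.3-fold higher number from compound 3 to compound 4 (0.36 log units; beyond the scatter). For compound 4 the estimate is 45000 nM, with an expected range of 20000 nM to 100000 nM.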

Compound 4, half-maximal inhibitory concentration: > 50000 nM
Compound 4: a limit, no number (the forecaster's own chance of this, stated with the estimate: 60%); middle value at least 1.1-fold (0.04 log units) away from the limit.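

an at least 2.5-fold higher number from compound 3 to compound 4 (0.40 log units; beyond the scatter), with 4-(methoxycarbonyl)piperidin-1-yl in place of 4-(butylamino)phenyl on a saturated chain carbon bound to a triple-bonded carbon. At this place, a second step now points the same way: of the four groups shown, only 4-(butylamino)phenyl gives a true number in this assay. The steps from compound 1 and compound 2 to compound 4 cannot be read because both ends of each are limits: the limit of > 50000 nM in this assay, at which 3 of the 4 values shown sit.

Whether the butylamino chain or the aromatic ring accounts for the difference remains open. An unsubstituted phenyl or a 4-aminophenyl group at this place would separate the two.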